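This account rests on a few compounds, and the source may have more. Where it says the series, first, only, none or still open, it means among the compounds named here.

Measured so far:
compound 1 `CCOc1cc(=O)n(CCCO)c2c1CC(C/C=C(\C)CCC=C(C)C)C(C)(C)C2`: 0.8%
compound 2 `COc1ccc(NC(=O)Oc2cc(=O)n(CCCO)c3c2CC(C/C=C(\C)CCC=C(C)C)C(C)(C)C3)cc1`: 0%

In a functional assay on PANC-1 cells (Homo sapiens) for inhibition, read by MTT assay, with a stated time of 24 h, tested at 10 uM (on this read-out lower numbers stand for less inhibition and higher numbers for more inhibition at the one concentration tested (going by the name of the read-out)), compound 2 gives 0%. Going by the values given here, its only neighbour is compound 1, and the step of a number 0.8 percentage points lower from compound 1 to compound 2 (within the scatter) lies within the scatter, so the two compounds do not stand apart in this assay. Compound 3 `COc1cccc(NC(=O)Oc2cc(=O)n(CCCO)c3c2CC(C/C=C(\C)CCC=C(C)C)C(C)(C)C3)c1` differs from compound 2 by 3-methoxyphenyl in place of 4-methoxyphenyl on an amide-type nitrogen. Among the compounds with values here, no measured step alters this group, so none bears directly on the change; the single step known, from a small ether to a carbamate, left the number essentially unmoved. Compound 3 is therefore expected to show no step beyond the scatter, a number 2 percentage points higher from compound 2 to compound 3 (within the scatter). The estimate for compound 3 is 2%, ranging from 0% to 12%.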

Compound 3, a percentage reported as inhibition, at one concentration (the size of the read-out at that concentration, not a potency): 11.3%
Compound 3: middle estimate off by 9.3 percentage points, on the low side, within the range that was stated.
By their numbers in this assay, from the lowest: compounds 2 and 1 (each within the scatter of the next); then compound 3.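

In this assay, going by these compounds alone, the placement of the methoxy group on the phenyl ring matters: 3-methoxyphenyl in place of 4-methoxyphenyl gives a number 11.3 percentage points higher from compound 2 to compound 3 (beyond the scatter) and is the first change to go beyond the scatter. Replacing ethyl with (3-methoxyphenyl)carbamoyl likewise gives a number 10.5 percentage points higher from compound 1 to compound 3 (beyond the scatter) whereas the (4-methoxyphenyl)carbamoyl group gave only a number 0.8 percentage points lower from compound 1 to compound 2 (within the scatter) within the scatter. No available evidence accounts for this difference.

Going by these compounds, it remains open whether the methoxy group itself is needed on that ring. A 3-aminophenyl or 3-carboxyphenyl group on the amide-type nitrogen could answer this.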